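A trifluoromethyl swap on compound 3

A few compounds are considered here, and "the series" means these few. Any claim that something is new, unique, unknown or untested is made for them only; others in the source may bear on it.

Measured in a functional assay on HeLa cells (Homo sapiens) for inhibition; on this read-out lower numbers stand for stronger inhibition of growth and higher numbers for weaker inhibition of growth:
- compound 1 `O=C(OCc1ccccc1)c1ccsc1NC(=O)[C@@H]1CCCN1`: > 250 ug/mL, a limit of the assay
- compound 2 `CCOC(=O)c1ccsc1NC(=O)[C@@H]1CCCN1`: 35.3 ug/mL
- compound 3 `O=C1CC[C@@H](COC(=O)c2ccsc2NC(=O)[C@@H]2CCCN2)N1`: 191 ug/mL

Of the two exact numbers in this assay, that of compound 3 is the higher. Compound 4 `O=C(OCC(F)(F)F)c1ccsc1NC(=O)[C@@H]1CCCN1` differs from it as follows: trifluoromethyl in place of 5-oxopyrrolidin-2-yl on a saturated chain carbon bound to an oxygen next to a carbonyl group. The closest guide replaced methyl with 5-oxopyrrolidin-2-yl, giving a 5.4-fold higher number from compound 2 to compound 3 (0.73 log units; beyond the scatter). The steps of an at least 7.0-fold lower number from compound 1 to compound 2 (0.85 log units; beyond the scatter) and an at least 1.3-fold lower number from compound 1 to compound 3 (0.11 log units; that floor lies within the scatter) start from the limit of > 250 ug/mL in this assay, at which 1 of the 3 values shown sits, so they give floors only. Trifluoromethyl is not methyl, but a modest move towards a lower number is expected, and the expected step is a 3.2-fold lower number from compound 3 to compound 4 (0.50 log units; beyond the scatter). Compound 4 is estimated at 60 ug/mL, with an expected range of 18 ug/mL to 190 ug/mL.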

Compound 4, concentration for 50% growth inhibition: 109 ug/mL
For compound 4 the middle estimate is 1.8-fold (0.26 log units) below the measured one, and the stated range covers the measured number.
By their numbers in this assay, from the lowest: compound 2; then compounds 4 and 3 (each within the scatter of the next). At a limit, above all of these: compound 1.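

In this assay, trifluoromethyl and 5-oxopyrrolidin-2-yl are not told apart at this position: a 1.8-fold lower number from compound 3 to compound 4 (0.24 log units; within the scatter). Trifluoromethyl does not stand in for methyl, however: a 3.1-fold higher number from compound 2 to compound 4 (0.49 log units; beyond the scatter). Compound 1 is a limit, so against phenyl only a floor can be read: an at least 2.2-fold lower number from compound 1 to compound 4 (0.36 log units; beyond the scatter).

As far as these compounds go, it remains open whether any group other than methyl reaches a number as low as that of compound 2 at this position. From the compounds shown here alone, how an amine, a carboxylic acid or a longer chain such as propyl would read there also remains open.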